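Ester variation on a naphthoquinone core against DU-145 cells

A few compounds are considered here, and "the series" means these few. Any claim that something is new, unique, unknown or untested is made for them only; others in the source may bear on it.

Measured compounds:
Compound 1 `CC(C)=CC[C@@H](OC(=O)CCO)C1=CC(=O)c2c(O)ccc(O)c2C1=O`: 55300 nM
Compound 2 `CCCCCCC(C)(O)CC(=O)O[C@H](CC=C(C)C)C1=CC(=O)c2c(O)ccc(O)c2C1=O`: > 100000 nM

The study compares esters of a shared core in a functional assay on DU-145 cells (Homo sapiens) for cytotoxicity, read by MTT assay; a higher number here means a weaker inhibitor, a lower number a stronger inhibitor. In this assay, among the measured compounds shown here, compound 1 gives 55300 nM, the only number recorded here. Compound 2 reaches only a limit of the assay in this assay, at > 100000 nM, so the step of an at least 1.8-fold higher number from compound 1 to compound 2 (0.25 log units; that floor lies within the scatter) has a floor that stays within the scatter, as shown by the limit of > 100000 nM in this assay, at which 1 of the 2 values shown sits. For the measured compounds named here, compound 1 therefore stands as the one compound with a definite number, and a weak one.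

Compound 3 `CC(C)=CC[C@@H](OC(=O)C1CCOC1)C1=CC(=O)c2c(O)ccc(O)c2C1=O` is not yet measured. It differs from compound 1 by oxolan-3-yl in place of 2-hydroxyethyl on a carbonyl carbon. Going by the values given here, no measured step bears directly on this change: the only step recorded alters a different part of the acyl chain. With compound 1 weak and compound 2 at the limit, compound 3 is expected to stay near compound 1, with a step of a 1.1-fold higher number from compound 1 to compound 3 (0.04 log units; within the scatter) that lies within the scatter. Compound 3 is estimated at 60000 nM, between 25000 nM and 150000 nM.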

Compound 3, half-maximal inhibitory concentration: 47500 nM
For compound 3 the middle estimate is 1.3-fold (0.10 log units) above the measured one, within the range that was stated.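

In this assay, the step at this carbonyl carbon is a 1.2-fold lower number from compound 1 to compound 3 (0.07 log units; within the scatter), so a five-membered ring with no hydrogen-bond donor in place of the open 2-hydroxyethyl group leaves compound 1 and compound 3 indistinguishable. Set against the 2-hydroxy-2-methyloctyl group, oxolan-3-yl gives an at least 2.1-fold lower number from compound 2 to compound 3 (0.32 log units; beyond the scatter), the first step in this set that clears the scatter. The reading for compound 2 is a limit of the assay and not a number, so that step has only a floor: the limit of > 100000 nM in this assay, at which 1 of the 3 values shown sits.

On these data alone, whether an amine or a carboxylic acid on this carbonyl carbon would move the number beyond the scatter stays open. So does the question of how long a chain can grow here before the reading reaches that limit.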